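The source may hold more compounds than are shown below. What is called first, only, known or untested is meant among the compounds shown, and "the series" means these compounds.

Compound 1 `CNCCNCc1cccc(-c2nc(Nc3ccccc3)c(C)c(-c3c(C)nn(C)c3C)n2)c1` and compound 2 `CNCCNCc1cccc(-c2nc(NC3CCOCC3)c(C)c(-c3cccnc3)n2)c1` have both been measured in a functional assay on A-375 cells (Homo sapiens) for inhibition, read by sulforhodamine B assay, with a stated time of 6 days; on this read-out lower numbers stand for stronger inhibition and higher numbers for weaker inhibition. There compound 1 gives 6700 nM and compound 2 gives 45500 nM, so compound 2 holds the higher of the two numbers, meaning weaker inhibition, and the gap lies beyond the scatter. The two differ in more than one place, so no single-change comparison is available yet. Compound 3 `CNCCNCc1cccc(-c2nc(Nc3ccccc3)c(C)c(-c3cccnc3)n2)c1` is compound 2 with one change: phenyl in place of oxan-4-yl on a nitrogen on an aromatic ring. Compound 1 also carries the anilino group and reads 6700 nM, which suggests a move toward stronger inhibition, although this rests on a single compound. The expected step is a 4.1-fold lower number from compound 2 to compound 3 (0.62 log units; beyond the scatter), an estimate pointing to a lower number, beyond the scatter. For compound 3 the estimated value is 11000 nM, with an expected range from 3500 nM to 30000 nM.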

Compound 3, half-maximal inhibitory concentration: 10900 nM
Estimate against measurement, compound 3: 1.0-fold (0.00 log units) above; the range from low to high includes it.
By their numbers in this assay, from the lowest: compounds 1 and 3 (each within the scatter of the next); then compound 2.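

In this assay, phenyl in place of oxan-4-yl on the nitrogen gives a 4.2-fold lower number from compound 2 to compound 3 (0.62 log units; beyond the scatter) with the rest of the molecule held fixed, so the group at this position does change the reading. That single swap changes two things at once, since a non-aromatic ring with an oxygen gives way to an aromatic ring of carbon only, and the step cannot separate them. With the anilino group kept, pyridin-3-yl in place of 1,3,5-trimethyl-1H-pyrazol-4-yl gives a 1.6-fold higher number from compound 1 to compound 3 (0.21 log units; within the scatter) and so shows no difference between these two groups on the aromatic carbon.

Cyclohexyl on the same nitrogen, a non-aromatic ring of carbon only, would show which of those two things matters. Also open, as far as these compounds go, is how a phenyl ring carrying a chlorine or a methoxy group would read. Nothing available here accounts for either step.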